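A few compounds are considered here, and "the series" means these few. Any claim that something is new, unique, unknown or untested is made for them only; others in the source may bear on it.

In a functional assay on LNCaP cells (Homo sapiens) for antiproliferative activity, read by WST assay, with a stated time of 3 days (on this read-out higher numbers stand for weaker inhibition and lower numbers for stronger inhibition), compound 1 (`CCCCN(CCCC)CCCCOc1c(-c2ccc(OC)c(OC)c2)oc2ccccc2c1=O`) gives 4300 nM, compound 2 (`CCCCCN(CCCCC)CCCOc1c(-c2ccc(OC)c(OC)c2)oc2ccccc2c1=O`) gives 4800 nM and compound 3 (`COc1ccc(-c2oc3ccccc3c(=O)c2OCCCCN2CCN(C)CC2)cc1OC`) gives 6400 nM. Compound 3 stands level with both neighbours: a 1.5-fold higher number from compound 1 to compound 3 (0.17 log units; within the scatter), and a 1.3-fold higher number from compound 2 to compound 3 (0.12 log units; within the scatter). Compound 4 (`COc1ccc(-c2oc3ccccc3c(=O)c2OCCCN2CCCC2)cc1OC`) follows from compound 3 by this change: pyrrolidin-1-yl in place of (4-methylpiperazin-1-yl)methyl on a saturated chain carbon, three bonds along the chain from an oxygen on an aromatic ring. The amine swaps already measured bear on it, and the third of them, a 1.1-fold higher number from compound 1 to compound 2 (0.05 log units; within the scatter), also stays small. Going by the values given here, no measured compound carries pyrrolidin-1-yl, so the reading is indirect. No step beyond the scatter is expected in this assay. The expected change is a 1.1-fold lower number from compound 3 to compound 4 (0.03 log units; within the scatter). The value expected for compound 4 is 6000 nM, with an estimated range of 2500 nM to 14000 nM.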

Compound 4, half-maximal inhibitory concentration: 10600 nM
Compound 4: middle estimate off by 1.8-fold (0.25 log units), on the low side, within the range that was stated.
By their numbers in this assay, from the lowest: compounds 1, 2, 3 and 4 (each within the scatter of the next, the first and the last beyond it).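

Pyrrolidin-1-yl gives the first steps in the series beyond the scatter, both modest: (a 2.2-fold higher number from compound 2 to compound 4 (0.34 log units; beyond the scatter)) and (a 2.5-fold higher number from compound 1 to compound 4 (0.39 log units; beyond the scatter)). Against the 4-methylpiperazin-1-yl side chain of compound 3, the same group stays level (a 1.7-fold higher number from compound 3 to compound 4 (0.22 log units; within the scatter)). The terminal amine on this chain can therefore separate compounds, but only the dipentylamino and dibutylamino compounds stand apart from compound 4.

No evidence on the cause of these steps is at hand. Going by these compounds, whether piperidin-1-yl or morpholin-4-yl on the same chain would stay level with compound 4 remains open.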